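Aryl change on the carbonyl carbon: half-life notes

The compounds below may be only part of what the source reports. "The series", "measured", "known", "first", "only" and "open" are said of these compounds alone.

Measured so far in an ADME assay on blood (Homo sapiens) for pharmacokinetics; on this read-out higher numbers stand for a longer-lived compound and lower numbers for a shorter-lived compound:
compound 1 `COC(=O)CCNC(=O)[C@@H]1O[P@@](=O)(OCOC(=O)c2ocnc2C)OCC1(C)C` — 0.52 h
compound 2 `COC(=O)CCNC(=O)[C@@H]1O[P@](=O)(OCOC(=O)c2ocnc2C)OCC1(C)C` — 0.27 h

Going by the values given here, compound 1 stands at the top of the two numbers, but the only measured step, a 1.9-fold lower number from compound 1 to compound 2 (0.28 log units; within the scatter), lies within the scatter and rests on the fact that compounds 1 and 2 differ only in the configuration as drawn alone. Compound 3 `COC(=O)CCNC(=O)[C@@H]1O[P@@](=O)(OCOC(=O)c2scnc2C(C)(C)C)OCC1(C)C` carries 4-(tert-butyl)-1,3-thiazol-5-yl in place of 4-methyl-1,3-oxazol-5-yl on a carbonyl carbon. Among the compounds with values here, no measured step concerns this kind of change, so the expectation leans on compound 1 by itself: the step of a 1.2-fold higher number from compound 1 to compound 3 (0.06 log units; within the scatter) is expected to stay within the scatter, with no direction chosen. Compound 3 is therefore estimated at 0.6 h, with a range from 0.3 h to 1.4 h to reflect the untested change.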

Compound 3, half-life: > 1 h
Compound 3: only a limit was reported (the forecaster's own chance of this, stated with the estimate: 5%); middle value at least 1.6-fold (0.22 log units) away from the limit.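

Exchanging 4-methyl-1,3-oxazol-5-yl for 4-(tert-butyl)-1,3-thiazol-5-yl on this carbonyl carbon gives an at least 1.9-fold higher number from compound 1 to compound 3 (0.28 log units; that floor lies within the scatter) in this assay for this first reading of a change at this position. For compound 3, > 1 h is a limit of the assay and not a number, so only a floor for the step can be read.

The ring and the tert-butyl group change together, leaving open which carries the step; a 4-methyl-1,3-thiazol-5-yl group on the same carbonyl carbon would separate them. As far as these compounds go, how the phosphorus configuration behaves with the new group also stays open.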